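A few compounds are considered here, and "the series" means these few. Any claim that something is new, unique, unknown or untested is made for them only; others in the source may bear on it.

Of the compounds shown here, three that share one core have been measured in a functional assay on CHO cells for agonist activity at Alpha-1A adrenergic receptor (Homo sapiens), read by FLIPR and calcium flux; on this read-out higher numbers stand for larger maximal responses and lower numbers for smaller maximal responses. Compound 1 `c1cc(-c2cn[nH]c2)c2c(c1)C(c1ncc[nH]1)CC2` gives 84%. Compound 2 `CCS(=O)(=O)Nc1cccc2c1CCC2c1ncc[nH]1`, which carries (ethylsulfonyl)amino in place of 1H-pyrazol-4-yl on an aromatic carbon, gives 86%; the step is a number 2 percentage points higher from compound 1 to compound 2 (within the scatter). Compound 3 `c1ccc(-c2cccc3c2CCC3c2ncc[nH]2)nc1` gives 53%, the lowest of the three numbers, as the steps of a number 31 percentage points lower from compound 1 to compound 3 (beyond the scatter) and a number 33 percentage points lower from compound 2 to compound 3 (beyond the scatter) show.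

Compound 4 `c1ccc2c(c1)CCC2c1ncc[nH]1` has not yet been measured. It differs from compound 3 in one place: hydrogen in place of pyridin-2-yl on an aromatic carbon. The two steps that bear on this are the ones that brought pyridin-2-yl in, and both lowered the maximal response by a large amount, while the two other substituents gave numbers within the scatter of each other. Within the data shown here, removing pyridin-2-yl is therefore expected to raise the response back toward the level of compounds 1 and 2, although hydrogen has no direct precedent among the three measured compounds, so the range is kept wide. Compound 4 is expected to reach 75%, with a range from 50% to 95%. The expected step is a number 22 percentage points higher from compound 3 to compound 4 (beyond the scatter).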

Compound 4, largest response reached (Emax), in percent of the reference or control that the assay uses: 54%
Compound 4: middle estimate off by 21 percentage points, on the high side; low and high end bracket the measured number.
By their numbers in this assay, from the lowest: compounds 3 and 4 (each within the scatter of the next); then compounds 1 and 2 (each within the scatter of the next).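

Hydrogen in place of pyridin-2-yl gives a result that cannot be told apart from compound 3 in this assay (a number 1 percentage points higher from compound 3 to compound 4 (within the scatter)), so the unsubstituted position serves as a baseline. Against that baseline, the large drops seen earlier with pyridin-2-yl read differently: hydrogen in place of (ethylsulfonyl)amino gives (a number 32 percentage points lower from compound 2 to compound 4 (beyond the scatter)) and hydrogen in place of 1H-pyrazol-4-yl gives (a number 30 percentage points lower from compound 1 to compound 4 (beyond the scatter)). The higher maximal response therefore goes with having (ethylsulfonyl)amino or 1H-pyrazol-4-yl on this aromatic carbon, whereas pyridin-2-yl stays within the scatter of hydrogen.

Nothing available here explains why these groups differ. On these data alone, it remains open whether a smaller group on this carbon, such as an amine or a methoxy group, would stay with hydrogen and pyridin-2-yl or join the higher pair.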